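Notes on a sulfonamide ether-amide series: microsomal stability

The source may report more compounds than this note shows. Statements on the series, on what has been measured and on what is new or still open speak of the compounds shown alone.

Measured so far:
- compound 1 `COc1cc(C)c(S(=O)(=O)N(C)CCOCC(=O)N2CCC(N3CCN(C(C)C)CC3)CC2)c(C)c1` gives 54% in an ADME assay on microsomes from liver (Homo sapiens) for metabolic stability, with a stated time of 30 min, tested at 1 uM; on this read-out lower numbers stand for a less stable compound and higher numbers for a more stable compound
- compound 2 `CN(Cc1ccc(C2=NCCN2)cc1)C(=O)COCCN(C)S(=O)(=O)c1c(Cl)cccc1Cl` gives "not determined" (no result reported) in this assay

Within the data shown here, compound 1 is the only member with a number. Compound 2 stands nowhere on the numbers shown: this assay was run on it, but no value came back, so it cannot be placed against compound 1 or against the scatter.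

Compound 3 `Cc1c(Cl)ccc(S(=O)(=O)N(C)CCOCC(=O)N(C)Cc2ccc(C3=NCCN3)cc2)c1Cl` is the next member and is still to be measured. It differs from compound 2 in one place: 2,4-dichloro-3-methylphenyl in place of 2,6-dichlorophenyl on a sulfonyl sulfur. The rest of the molecule is kept.

With no number for compound 2, the step to compound 3 in this assay cannot be sized or given a direction from the data; a change of this kind on the sulfonyl aryl group is expected to move the read-out by no more than the scatter, if at all, but this is an expectation without an anchor. Among the measured compounds shown here, the only reference point is compound 1, which gives 54% in this assay.

Compound 3 is therefore expected to give roughly 45% in this assay, with a range from 15% to 80%.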

Compound 3, percent of the compound remaining: 8%
For compound 3 the middle estimate is 37 percentage points above the measured one; the whole stated range lies above it.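

In this assay, among these compounds, compound 3 gives 8% but compound 2 has no number, so no step between the two can be read. Nothing measured here accounts for this value. The compounds shown leave open how 2,4-dichloro-3-methylphenyl in place of 2,6-dichlorophenyl on a sulfonyl sulfur moves this read-out.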